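Thioamide-bearing replacement on the ring amine of compound 1

The source may report more compounds than this note shows. Statements on the series, on what has been measured and on what is new or still open speak of the compounds shown alone.

Compound 1, `NC(=O)c1c(NC(=O)c2ccccc2Cl)sc2c1CCN(Cc1ccc(Cl)cc1)C2`: 22500 nM
Compound 2, `NC(=O)c1c(NC(=O)c2ccc(C(F)(F)F)cc2)sc2c1CCN(Cc1c(Cl)cccc1Cl)C2`: 10600 nM

In a functional assay on HL-60 cells (Homo sapiens) for antiproliferative activity, with a stated time of 24 h (on this read-out higher numbers stand for weaker inhibition and lower numbers for stronger inhibition), compound 1 gives 22500 nM, the highest of the two numbers; its nearest neighbour, compound 2, gives 10600 nM, and that gap is beyond the scatter. Compound 2 differs from compound 1 in more than one place, so the two values show only that both are weak inhibitors here.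

Compound 3, `CSc1ccccc1NC(=S)N1CCc2c(sc(NC(=O)c3ccccc3Cl)c2C(N)=O)C1`, has not been measured. It differs from compound 1 as follows: a group of 11 heavy atoms (8 carbon, 1 nitrogen, 2 sulfur; one six-membered aromatic ring of carbon only) in place of a group of 8 heavy atoms (7 carbon, 1 chlorine; one six-membered aromatic ring of carbon only), on an amine nitrogen in a ring. Within the data shown here, nothing among the measured compounds shows what this change does, since no single-step comparison is available. The step from compound 1 to compound 3 in this assay is therefore expected to be small, without a clear direction, and is estimated as a 1.5-fold lower number from compound 1 to compound 3 (0.18 log units; within the scatter). Compound 3 is expected to give about 15000 nM, in a range from 4000 nM to 60000 nM.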

Compound 3, half-maximal inhibitory concentration: 14600 nM
The estimate for compound 3 lay 1.0-fold (0.01 log units) above the measured number; measured number inside the range.
By their numbers in this assay, from the lowest: compounds 2, 3 and 1 (each within the scatter of the next, the first and the last beyond it).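

Among these compounds, the step from compound 1 to compound 3 is the first comparison in this assay that isolates the group on the amine nitrogen in a ring, and it amounts to a 1.5-fold lower number from compound 1 to compound 3 (0.19 log units; within the scatter). Within this single pair, the thioamide-bearing group, which has a hydrogen-bond donor and acceptors, and the 4-chlorobenzyl group, which has neither, cannot be told apart by their numbers. No measured evidence bears on why the two groups read alike.

Going by these compounds, it remains open whether a urea, with a carbonyl in place of the thiocarbonyl, or a plain phenyl in place of the methylthio-bearing phenyl, would give a number beyond the scatter from that of compound 3. Steps involving compound 2 cannot be read, since it differs from the others in more than one place.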